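The source may report more compounds than this note shows. Statements on the series, on what has been measured and on what is new or still open speak of the compounds shown alone.

Three compounds share one core, and each has been tested for displacement of a labelled ligand. In an assay on CHO cells for displacement of a labelled ligand from Alpha-2C adrenergic receptor (Homo sapiens) (on this read-out higher numbers stand for weaker inhibition and lower numbers for stronger inhibition), compound 1 `CC(Oc1ccccc1-c1ccc([N+](=O)[O-])cc1)C1=NCCN1` gives 302 nM. Compound 2 `CC(Oc1ccccc1-c1ccccc1O)C1=NCCN1` gives 1620 nM. Compound 3 `Cc1ccccc1-c1ccccc1OC(C)C1=NCCN1` gives 234 nM, the lowest number of the three; its gap to compound 1 lies within the usual scatter, while compound 2 sits clearly higher. Among the measured compounds shown here, the only single-place step among them is a 6.9-fold lower number from compound 2 to compound 3 (0.84 log units; beyond the scatter). Compound 4 `CC(Oc1ccccc1-c1ccc(O)cc1)C1=NCCN1` differs from compound 3 by 4-hydroxyphenyl in place of 2-methylphenyl on an aromatic carbon. A hydroxy group thus returns to this ring, so the number may climb back, yet compound 1 shows that another group on the same ring can stay close to compound 3. Compound 4 is therefore expected to give 700 nM, within 250 nM to 2000 nM, an estimated step of a 3.0-fold higher number from compound 3 to compound 4 (0.48 log units; beyond the scatter) in this assay.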

Compound 4, inhibition constant: 331 nM
For compound 4 the middle estimate is 2.1-fold (0.33 log units) above the measured one; low and high end bracket the measured number.
By their numbers in this assay, from the lowest: compounds 3, 1 and 4 (each within the scatter of the next); then compound 2.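

In this assay, 4-hydroxyphenyl stands level with 2-methylphenyl on this aromatic carbon, with a 1.4-fold higher number from compound 3 to compound 4 (0.15 log units; within the scatter), and hydroxy stands level with nitro, with a 1.1-fold higher number from compound 1 to compound 4 (0.04 log units; within the scatter). Replacing 2-hydroxyphenyl with 4-hydroxyphenyl gives a 4.9-fold lower number from compound 2 to compound 4 (0.69 log units; beyond the scatter), so in this pair the number depends on where the hydroxy group sits on the ring, not merely on its presence. Nothing given here explains that difference. As far as these compounds go, whether an amine or a carboxylic acid in place of the hydroxy on 4-hydroxyphenyl would give a similar number stays open.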